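Swapping the aryl group on the piperazine ring for pyridinylmethyl

This account rests on a few compounds, and the source may have more. Where it says the series, first, only, none or still open, it means among the compounds named here.

Of the compounds shown here, three sharing one core have been measured in a functional assay on MGC-803 cells (Homo sapiens) for antiproliferative activity, read by CCK-8 assay, with a stated time of 72 h, tested at 8 uM; a higher number here means a stronger effect of the compound at the concentration tested, a lower number a weaker effect. Compound 1 `Nc1ccccc1NC(=O)c1ccc(CSC(=S)N2CCN(c3ccccc3)CC2)cc1` gives 87.4%. Compound 2 `Nc1ccccc1NC(=O)c1ccc(CSC(=S)N2CCN(c3ccc(F)cc3)CC2)cc1` gives 48.7%, and compound 3 `Cc1ccc(N2CCN(C(=S)SCc3ccc(C(=O)Nc4ccccc4N)cc3)CC2)cc1` gives 19.8%. Compound 3 therefore stands lowest of the three, with compound 2 nearest and compound 1 furthest above it.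

Compound 4 `Nc1ccccc1NC(=O)c1ccc(CSC(=S)N2CCN(Cc3cccnc3)CC2)cc1` is the next step from compound 3: (pyridin-3-yl)methyl in place of 4-methylphenyl on an amine nitrogen in a ring.

The measured steps all concern substituents on that same aromatic ring rather than its replacement. Adding a substituent lowered the read-out, by a number 38.7 percentage points lower from compound 1 to compound 2 (beyond the scatter) and by a number 67.6 percentage points lower from compound 1 to compound 3 (beyond the scatter), and changing one substituent for another gave a number 28.9 percentage points lower from compound 2 to compound 3 (beyond the scatter). None of these steps involves exchanging the whole 4-methylphenyl for a (pyridin-3-yl)methyl group, so the direction for compound 4 rests only on the observation that compound 3 is the lowest point and that the unsubstituted-ring compound 1 sits far above it.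

On that basis compound 4 is expected to move upward, by a number 30.2 percentage points higher from compound 3 to compound 4 (beyond the scatter), in this assay. The estimate for compound 4 is 50%, with a range from 20% to 85%.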

Compound 4, a percentage reported as inhibition, at one concentration (the size of the read-out at that concentration, not a potency): 64.6%
Estimate against measurement, compound 4: 14.6 percentage points below; the measured number falls inside the stated range.
By their numbers in this assay, from the lowest: compound 3; then compound 2; then compound 4; then compound 1.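

In this assay, the ring amine nitrogen proves open to more than small edits on a phenyl ring: (pyridin-3-yl)methyl has the same count of heavy atoms as 4-methylphenyl, but it brings 1 hydrogen-bond acceptor and a ring with 1 hetero atom, and the read-out is a number 44.8 percentage points higher from compound 3 to compound 4 (beyond the scatter) in that exchange. The new group also compares well with the fluorinated ring, at a number 15.9 percentage points higher from compound 2 to compound 4 (beyond the scatter) for that exchange, yet it does not match the plain phenyl, being a number 22.8 percentage points lower from compound 1 to compound 4 (beyond the scatter) on that comparison, so compound 1 keeps the top place among these compounds. Nothing measured here gives a reason for these differences.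

This exchange alters the ring and its attachment together, so the compounds shown cannot say whether the added carbon link or the ring nitrogen accounts for the change. Benzyl would separate the two by keeping the link without the ring nitrogen, while pyridin-3-yl attached directly would do the reverse, and (pyridin-2-yl)methyl or (pyridin-4-yl)methyl would test whether the place of the ring nitrogen matters.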